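Trifluoromethoxy for bromo on a styryl chromone

The compounds below may be only part of what the source reports. "The series", "measured", "known", "first", "only" and "open" are said of these compounds alone.

Compound 1: `COc1cc(OC)c2c(=O)cc(/C=C/c3ccc(Cl)cc3)oc2c1`, > 40000 nM in a functional assay on PC-3 cells (Homo sapiens) for antiproliferative activity, read by MTT assay, with a stated time of 12 h (on this read-out higher numbers stand for weaker inhibition and lower numbers for stronger inhibition), a limit of the assay.
Compound 2: `COc1cc(OC)c2c(=O)cc(/C=C/c3ccc(Br)cc3)oc2c1`, > 40000 nM in this assay, a limit of the assay.

Compound 2 thus stands only at a limit, and the same is true of compound 1, so that the limit of > 40000 nM in this assay, at which 2 of the 2 values shown sit, describes both values shown. Within the data shown here, the one measured step, a step that the two limits leave unreadable from compound 1 to compound 2, cannot be read from these two limits. The change now followed is trifluoromethoxy in place of bromo on an aromatic carbon, giving compound 3, `COc1cc(OC)c2c(=O)cc(/C=C/c3ccc(OC(F)(F)F)cc3)oc2c1`. Among the measured compounds shown here, no measured step bears on this change, and the two limits give no direction from which to expect a step beyond the scatter. The estimate for compound 3 therefore rests on the limit of compound 2 alone: the value of compound 3 is expected to be 60000 nM, within 20000 nM to 200000 nM, most probably reported again as a limit. The expected step is then a step that the limit leaves unreadable from compound 2 to compound 3.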

Compound 3, half-maximal inhibitory concentration: > 40000 nM
Compound 3: no number, only a limit; the forecaster's own chance of this, stated with the estimate: 75%; the middle value does not contradict the limit.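

Compound 3 gives > 40000 nM in this assay, which is a limit of the assay. The steps to compound 3 from compound 1 and from compound 2 therefore cannot be read: the limit of > 40000 nM in this assay, at which 3 of the 3 values shown sit.

The compounds shown leave open whether chloro, bromo and trifluoromethoxy differ at all in this assay.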